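A few compounds are considered here, and "the series" means these few. Any claim that something is new, unique, unknown or untested is made for them only; others in the source may bear on it.

Measured in an ADME assay on CCRF-HSB-2 cells (Homo sapiens) for cytotoxicity, with a stated time of 7 days; on this read-out lower numbers stand for higher toxicity in this test and higher numbers for lower toxicity in this test:
- Compound 1 `C=CCOc1nc(N)nc2c1ncn2/C=C1/CC1(CO)CO`: > 20000 nM
- Compound 2 `COCCOc1nc(N)nc2c1ncn2/C=C1/CC1(CO)CO`: > 20000 nM
- Compound 3 `Nc1nc(NC2CCCCC2)c2ncn(/C=C3/CC3(CO)CO)c2n1`: > 20000 nM

Compound 3 gives > 20000 nM, which is a limit and not a number. It shares this position with the other two compounds, as the record shows (the limit of > 20000 nM in this assay, at which 3 of the 3 values shown sit).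

In compound 4 `CCCOc1nc(N)nc2c1ncn2/C=C1/CC1(CO)CO`, propoxy replaces cyclohexylamino on an aromatic carbon (propoxy in place of cyclohexylamino on an aromatic carbon). The closest measured changes run the other way, putting cyclohexylamino in place of allyloxy and of 2-methoxyethoxy. They are a step that the two limits leave unreadable from compound 1 to compound 3 and a step that the two limits leave unreadable from compound 2 to compound 3. Changing the chain on oxygen gives a step that the two limits leave unreadable from compound 1 to compound 2. None of these steps has a readable size, so they give no direction. Compound 4 most resembles compounds 1 and 2, so it is expected to stay in the same region, probably at the limit again, with no step beyond the usual scatter. The expected step is a step that the limit leaves unreadable from compound 3 to compound 4. For compound 4 the estimated value is 25000 nM, with an expected range from 12000 nM to 50000 nM.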

Compound 4, half-maximal cytotoxic concentration: > 20000 nM
Compound 4: no number, only a limit; the forecaster's own chance of this, stated with the estimate: 85%; the middle value lies beyond the limit too.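

Compound 4 also sits at a limit and not at a number, and its steps from compound 1, compound 2 and compound 3 cannot be read: the limit of > 20000 nM in this assay, at which 4 of the 4 values shown sit. The compounds shown leave open whether any of these groups on the shared core changes the outcome in this assay.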